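The source may hold more compounds than are shown below. What is called first, only, known or untested is meant among the compounds shown, and "the series" means these compounds.

Measured so far:
compound 1, `ClCc1ccc(Cn2cnc3c(Cl)ncnc32)cc1`, 260 nM
compound 2, `ClCc1ccc(Cn2cnc3nc(Cl)nc(Cl)c32)cc1`, 1440 nM
compound 3, `ClCc1ccc(Cn2cnc3c(Cl)nc(Cl)nc32)cc1`, 9120 nM

All three were tested in a functional assay on CAKI-1 cells (Homo sapiens) for cytotoxicity, read by sulforhodamine B assay, with a stated time of 48 h; on this read-out higher numbers stand for weaker inhibition of growth and lower numbers for stronger inhibition of growth. Compound 1 gives 260 nM, compound 3 gives 9120 nM, and compound 2 sits between them with 1440 nM. Compound 1 and compound 3 differ in one place: hydrogen in place of chloro on an aromatic carbon. That single change gave a 35-fold lower number from compound 3 to compound 1 (1.55 log units; beyond the scatter). Compound 2 has the same atoms as compound 3 joined differently, and the difference between the two cores is not broken down here.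

Compound 4, `ClCc1ccc(Cn2cnc3ncnc(Cl)c32)cc1`, has not yet been tested in this assay. It is related to compound 2 by the same change: hydrogen in place of chloro on an aromatic carbon. The surroundings of the changed carbon read identically in both cases, so this is the same change made on a different core. Because compound 3 to compound 1 gave a 35-fold lower number from compound 3 to compound 1 (1.55 log units; beyond the scatter), a lower number is expected here too, though the different core leaves the size uncertain and a smaller step is estimated: a 4.8-fold lower number from compound 2 to compound 4 (0.68 log units; beyond the scatter). Compound 4 is therefore expected to give about 300 nM, likely within 80 nM to 1200 nM.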

Compound 4, concentration for 50% growth inhibition: 1990 nM
Estimate against measurement, compound 4: 6.6-fold (0.82 log units) below; the whole stated range lies below it.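

On the core of compound 2, putting hydrogen in place of the chloro on the aromatic carbon between two ring nitrogen atoms gave a 1.4-fold higher number from compound 2 to compound 4 (0.14 log units; within the scatter), so on this core the swap produced no readable change in growth inhibition. Set beside the earlier step, the same swap did not carry over from one core to the other in this assay: the same change on two cores in this assay, a 35-fold lower number (1.55 log units; beyond the scatter) from compound 3 to compound 1 and a 1.4-fold higher number (0.14 log units; within the scatter) from compound 2 to compound 4, 48-fold (1.69 log units) apart, beyond the scatter of two such steps This shows that, for these four compounds, the effect of the swap depends on the core, but it does not show why, and two cores are too few to support a rule for any other core.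

The compounds shown leave open whether another group on that same aromatic carbon, such as an amine or a methoxy group, would also behave differently on the two cores. They also leave open how much the chloromethyl group present in all four contributes, which a comparison with a plain methyl group in its place could address.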